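The source may report more compounds than this note shows. Statements on the series, on what has been measured and on what is new or still open speak of the compounds shown alone.

Compound 2 `C=C1C[C@]23C[C@@]1(O)CC[C@H]2c1ccc(OS(=O)(=O)c2ccc(C)cc2)c(C)c1[C@@H]3Cn1cc(-c2ccc(C)cc2)nn1` has been examined in a functional assay on MCF7 cells (Homo sapiens) for cytotoxicity, read by MTT assay, with a stated time of 4 days; a lower number here means a stronger inhibitor, a higher number a weaker inhibitor. For compound 2 the result is a limit of the assay, > 20000 nM, and not a number. Among the compounds with values here, compound 1 `C=C1C[C@]23C[C@@]1(O)CC[C@H]2c1ccc(O)c(C)c1[C@@H]3Cn1cc(-c2ccccn2)nn1` is the only other member of the series measured in this assay. For compound 1 the outcome is likewise a limit, > 20000 nM. Within the data shown here, no step between the two measured compounds can be stated because the limit of > 20000 nM in this assay, at which 2 of the 2 values shown sit, leaves no number from which a difference could be read. Among the measured compounds shown here, compound 3 `C=C1C[C@]23C[C@@]1(O)CC[C@H]2c1ccc(OS(=O)(=O)c2ccc(C)cc2)c(C)c1[C@@H]3Cn1cc(-c2ccccn2)nn1` carries the change (pyridin-2-yl in place of 4-methylphenyl on an aromatic carbon), in words pyridin-2-yl in place of 4-methylphenyl on an aromatic carbon; the entering group is the one present in compound 1. With both measured compounds sitting at the limit, no step beyond the scatter is expected in either direction, and compound 3 is expected to return a limit as well. Compound 3 is estimated at 30000 nM, within a range from 10000 nM to 100000 nM. The step this estimate implies is expected to be a step that the limit leaves unreadable from compound 2 to compound 3.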

Compound 3, half-maximal inhibitory concentration: > 20000 nM
Compound 3: no number, only a limit; the forecaster's own chance of this, stated with the estimate: 85%; the middle value does not contradict the limit.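

No step can be read from compound 3 to compound 2 or compound 1 in this assay, because all three results are limits and not numbers: the limit of > 20000 nM in this assay, at which 3 of the 3 values shown sit.

The compounds shown leave open whether pyridin-2-yl in place of 4-methylphenyl, or (4-methylphenyl)sulfonyl in place of hydrogen on the oxygen, alters the result in this assay.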